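The source may hold more compounds than are shown below. What is called first, only, known or untested is meant among the compounds shown, and "the series" means these compounds.

Compound 1, `C[C@@H](O)CCn1nc2c(Br)c(Br)c(Br)c(Br)c2n1`: 102%
Compound 2, `CC(O)CCn1nc2c(Br)c(Br)c(Br)c(Br)c2n1`: 90%

Both numbers come from a functional assay on MCF7 cells (Homo sapiens) for antiproliferative activity, read by MTT assay, with a stated time of 24 h, tested at 50 uM; a lower number here means a stronger effect, a higher number a weaker effect of the compound at the concentration tested. Among the two measured compounds, compound 2 stands lowest, with compound 1 as its nearest neighbour. Within the data shown here, the step of a number 12 percentage points lower from compound 1 to compound 2 (beyond the scatter) is the only measured step, and it separates two compounds that share all atoms and bonds and differ only in that (the fact that one of compounds 1 and 2 is drawn with a defined configuration and the other without, at the place where they differ).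

Compound 3, `OCC(O)Cn1nc2c(Br)c(Br)c(Br)c(Br)c2n1`, has not yet been tested in this assay. It differs from compound 2 by 1,2-dihydroxyethyl in place of 2-hydroxypropyl on a saturated chain carbon bound to an aromatic nitrogen. Among the measured compounds shown here, no measured step speaks to this kind of change: the one step known, a number 12 percentage points lower from compound 1 to compound 2 (beyond the scatter), concerns the drawn configuration at a chain carbon, not the exchange of one group for another. For the measured compounds named here, the only guide is therefore the value of compound 2 itself, and a step of no size beyond the scatter is expected, in no particular direction. The expected step is therefore no change at the digits printed from compound 2 to compound 3 (within the scatter). Compound 3 is estimated at 90%, within a range from 75% to 105%.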

Compound 3, a percentage reported as activity, at one concentration (the size of the read-out at that concentration, not a potency): 98%
Compound 3: the middle estimate sits 8 percentage points below what was measured, and the stated range covers the measured number.
By their numbers in this assay, from the lowest: compounds 2, 3 and 1 (each within the scatter of the next, the first and the last beyond it).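

In this assay, among these compounds, the first exchange of one group for another at this position, 1,2-dihydroxyethyl in place of 2-hydroxypropyl on a saturated chain carbon bound to an aromatic nitrogen, gives a number 8 percentage points higher from compound 2 to compound 3 (within the scatter), and the same exchange measured against the compound with the drawn configuration gives a number 4 percentage points lower from compound 1 to compound 3 (within the scatter). So a change of chain that swaps a carbon for an oxygen, taking the group from 1 hydrogen-bond donor and 1 acceptor to 2 of each, does not separate compound 3 from either neighbour, even though compound 1 and compound 2 do stand apart beyond the scatter. Among the compounds shown here, no available observation accounts for this lack of separation, as the only supporting information concerns the drawn configuration of the two earlier compounds and not this exchange.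

As far as these compounds go, whether an amine, a carboxylic acid or a longer chain at this place would move the number beyond the scatter remains open. Also open, from the compounds shown here alone, is whether a drawn configuration at the hydroxyl-bearing carbon of the 1,2-dihydroxyethyl chain would matter as it does between compound 1 and compound 2.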